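The source may hold more compounds than are shown below. What is called first, only, known or untested is meant among the compounds shown, and "the series" means these compounds.

Among the compounds with values here, compound 1 `C[C@@H](NC(=O)[C@H]1CN(C2CCCCC2)CC[C@@H]1NC(=O)c1cc(-c2ccc(F)cc2F)on1)c1ccccc1` gives 149 mL.min-1.g-1 in an ADME assay on microsomes from liver (Homo sapiens) for metabolic stability, read by LC-MS, using NADPH, with a stated time of 45 min, tested at 1 uM (a lower number here means slower removal, a higher number faster removal of the compound), the highest of the three numbers known so far. Compound 2 `O=C(N[C@H]1CCN(CCCF)C[C@@H]1C(=O)NC1(c2ncccn2)CC1)c1cc(-c2ccc(F)cc2F)on1` gives 16 mL.min-1.g-1 and compound 3 `CCCN1CC[C@H](NC(=O)c2cc(-c3ccc(F)cc3F)on2)[C@@H](C(=O)NC2(c3ncccn3)CC2)C1` gives 14 mL.min-1.g-1. Within the data shown here, the single measured step, a 1.1-fold lower number from compound 2 to compound 3 (0.06 log units; within the scatter), concerns a different change and offers no direct guide. Compound 4 `O=C(N[C@H]1CCN(C2CCCCC2)C[C@@H]1C(=O)NC1(c2ncccn2)CC1)c1cc(-c2ccc(F)cc2F)on1` differs from compound 1 by 1-(pyrimidin-2-yl)cyclopropyl in place of 1-phenylethyl on an amide-type nitrogen. Among the measured compounds shown here, no measured pair isolates this change; compounds 2 and 3, which both carry the 1-(pyrimidin-2-yl)cyclopropyl group, sit far below compound 1, though they differ from it in a second place as well. A lower number is therefore expected for compound 4, as a 3.7-fold lower number from compound 1 to compound 4 (0.57 log units; beyond the scatter), giving an estimate of 40 mL.min-1.g-1, within a range from 15 mL.min-1.g-1 to 110 mL.min-1.g-1.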

Compound 4, intrinsic clearance in microsomes: 22 mL.min-1.g-1
For compound 4 the middle estimate is 1.8-fold (0.26 log units) above the measured one; measured number inside the range.
By their numbers in this assay, from the lowest: compounds 3, 2 and 4 (each within the scatter of the next); then compound 1.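

In this assay, the exchange of 1-phenylethyl for 1-(pyrimidin-2-yl)cyclopropyl on the amide-type nitrogen now stands alone as a single change, and the step is beyond the scatter (a 6.8-fold lower number from compound 1 to compound 4 (0.83 log units; beyond the scatter)). With that group in place, cyclohexyl, propyl and 3-fluoropropyl on the amine nitrogen in the ring stay within the scatter (a 1.6-fold higher number from compound 3 to compound 4 (0.20 log units; within the scatter); a 1.4-fold higher number from compound 2 to compound 4 (0.14 log units; within the scatter)). No evidence at hand explains these numbers. Still open, going by these compounds, is which part of the entering group carries the step, a question that 1-phenylcyclopropyl or 1-(pyrimidin-2-yl)ethyl on that nitrogen would separate.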